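One Methoxy Group Less, and What the Cells May Show

The source may report more compounds than this note shows. Statements on the series, on what has been measured and on what is new or still open speak of the compounds shown alone.

Measured so far in a functional assay on SR cells (Homo sapiens) for cytotoxicity, read by sulforhodamine B assay, with a stated time of 48 h, tested at 0.1 uM; on this read-out lower numbers stand for a stronger effect and higher numbers for a weaker effect at the one concentration tested:
compound 1, `COc1ccc(-c2cc(/C=C/C(=O)c3ccc(N)cc3)[nH]n2)cc1`, gives 98%;
compound 2, `COc1ccc(-c2cc(/C=C/C(=O)c3ccc(N)cc3)[nH]n2)cc1OC`, gives 104%;
compound 3, `COc1cc(C(=O)/C=C/c2cc(-c3cc(OC)c(OC)c(OC)c3)n[nH]2)cc(OC)c1OC`, gives 93%.

All three numbers lie close together, so at this one concentration none of them cuts growth much. The difference between compound 2 and compound 1 is hydrogen in place of methoxy on an aromatic carbon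
and it gives a number 6 percentage points lower from compound 2 to compound 1 (within the scatter). Compound 4, `COc1ccc(-c2cc(/C=C/C(=O)c3cc(OC)c(OC)c(OC)c3)[nH]n2)cc1OC`, is not yet measured; it differs from compound 3 by hydrogen in place of methoxy on an aromatic carbon
The same kind of change, though the place here is also meta to a methoxy group. The cores of compound 2 and compound 3 are not broken down here. Because a number 6 percentage points lower from compound 2 to compound 1 (within the scatter) is small, compound 4 is expected to move only a number 2 percentage points higher from compound 3 to compound 4 (within the scatter). The estimate for compound 4 is 95%, between 84% and 106%.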

Compound 4, a percentage reported as activity, at one concentration (the size of the read-out at that concentration, not a potency): 73%
The estimate for compound 4 lay 22 percentage points above the measured number; measured number below the stated range.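

Removing one methoxy group and leaving hydrogen gives a number 20 percentage points lower from compound 3 to compound 4 (beyond the scatter) in this assay. Set beside the same change on the other core, this step cannot be told apart from the earlier one, so the change may carry over between these two cores: the same change on two cores in this assay, a number 6 percentage points lower (within the scatter) from compound 2 to compound 1 and a number 20 percentage points lower (beyond the scatter) from compound 3 to compound 4, 14 percentage points apart, within the scatter of two such steps

This does not show that the change has one fixed size, since two cores are few and a single concentration gives no measure of potency.

The compounds shown leave open what a hydroxyl group or a fluorine atom would do at this place on the ring. They also leave open whether the lower number of compound 4 would hold at other concentrations.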